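From (2,6-dimethylmorpholin-4-yl)methyl to isopropoxy on a carbonyl carbon

The source may report more compounds than this note shows. Statements on the series, on what has been measured and on what is new or still open speak of the compounds shown alone.

Of the compounds shown here, two with a shared core have so far been measured in a physicochemical assay for solubility, in phosphate buffer, with a stated time of 18 h, at pH 7.4; a higher number here means a more soluble compound, a lower number a less soluble compound. Compound 1 (`COc1cc2ncnc(-n3nc(-c4ccccn4)nc3N)c2cc1[N+](=O)[O-]`) gives 2000 nM, and compound 2 (`COc1cc2ncnc(-n3nc(-c4ccccn4)nc3N)c2cc1OCCCNC(=O)CN1C[C@@H](C)O[C@@H](C)C1`) gives 34000 nM. Compound 2 thus holds the higher of the two numbers, and its distance from compound 1 lies beyond the usual scatter of such measurements.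

Compound 3 (`COc1cc2ncnc(-n3nc(-c4ccccn4)nc3N)c2cc1OCCCNC(=O)OC(C)C`) has not yet been measured. It carries isopropoxy in place of the (2,6-dimethylmorpholin-4-yl)methyl of compound 2 on a carbonyl carbon (isopropoxy in place of (2,6-dimethylmorpholin-4-yl)methyl on a carbonyl carbon). For the measured compounds named here, no measured pair shows this change on its own, so any expectation remains loose. With only compound 1 at 2000 nM and compound 2 at 34000 nM to go on, a downward step beyond the scatter is expected in this assay, with compound 3 landing between those two values. The estimated change is an 8.5-fold lower number from compound 2 to compound 3 (0.93 log units; beyond the scatter). The expected solubility of compound 3 is 4000 nM, with an estimated range of 1000 nM to 15000 nM.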

Compound 3, solubility: 18000 nM
The estimate for compound 3 lay 4.5-fold (0.65 log units) below the measured number, and the stated range ends below it.
By their numbers in this assay, from the lowest: compound 1; then compounds 3 and 2 (each within the scatter of the next).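

In this assay, isopropoxy in place of (2,6-dimethylmorpholin-4-yl)methyl on a carbonyl carbon, whose other neighbour is an amide-type nitrogen, gives a 1.9-fold lower number from compound 2 to compound 3 (0.28 log units; within the scatter), so this assay does not separate the two groups at this place, even though the group that leaves has 9 heavy atoms and a six-membered non-aromatic ring and the one that enters has 4 heavy atoms and no ring. The second step, with 3-((isopropoxycarbonyl)amino)propoxy in place of nitro on an aromatic carbon, gives a 9.0-fold higher number from compound 1 to compound 3 (0.95 log units; beyond the scatter), which shows that a separation from compound 1 beyond the scatter persists without the (2,6-dimethylmorpholin-4-yl)methyl group. No measurement is available that would explain either step.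

The compounds shown leave open how a simple amine or a carboxylic acid would read on this carbonyl carbon, since only two groups have been compared there. They also leave open whether a longer chain in place of the propoxy linker would change the number, because the step from compound 1 replaces the nitro group with the chain and its end group together.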